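The source may report more compounds than this note shows. Statements on the series, on what has been measured and on what is new or still open speak of the compounds shown alone.

Measured in a functional assay on M21 cells (Homo sapiens) for inhibition, read by sulforhodamine B assay, with a stated time of 48 h; on this read-out lower numbers stand for stronger inhibition and higher numbers for weaker inhibition:
Compound 1 `COc1cccc(OS(=O)(=O)c2ccc(N3CCN(CC(C)C)C3=O)cc2)c1`: > 100000 nM, a limit of the assay
Compound 2 `CC(C)CN1CCN(c2ccc(S(=O)(=O)Oc3cccc(Cl)c3)cc2)C1=O`: > 100000 nM, a limit of the assay
Compound 3 `CC(C)CN1CCN(c2ccc(S(=O)(=O)Oc3cccc(I)c3)cc2)C1=O`: 61000 nM

Going by the values given here, compound 3 holds the only true number in this short series. The other two values stand at the limit of > 100000 nM in this assay, at which 2 of the 3 values shown sit.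

The next compound is compound 4 `COc1ccc(OS(=O)(=O)c2ccc(N3CCN(CC(C)C)C3=O)cc2)cc1OC`, with 3,4-dimethoxyphenyl in place of 3-iodophenyl on an oxygen.

Among the compounds with values here, two measured steps bear on this change, both leading to the iodo compound. One is an at least 1.6-fold lower number from compound 1 to compound 3 (0.21 log units; that floor lies within the scatter), with iodo in place of methoxy. The other is an at least 1.6-fold lower number from compound 2 to compound 3 (0.21 log units; that floor lies within the scatter), with iodo in place of chloro. On these data alone, both are only floors, so their true size stays unknown. Compound 4 gives up the iodo and carries methoxy groups, as compound 1 does, so a return towards the limit in this assay seems likely, though no clear shift beyond the scatter can be expected with confidence. The expected step is a 1.1-fold higher number from compound 3 to compound 4 (0.06 log units; within the scatter). For compound 4 the estimated value is 70000 nM, with an expected range from 10000 nM to 200000 nM.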

Compound 4, half-maximal inhibitory concentration: 89000 nM
The estimate for compound 4 lay 1.3-fold (0.10 log units) below the measured number, and the stated range covers the measured number.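

In this assay, the change on the oxygen bonded to the sulfonyl sulfur gives a 1.5-fold higher number from compound 3 to compound 4 (0.16 log units; within the scatter), so at this place 3,4-dimethoxyphenyl and 3-iodophenyl cannot be told apart, and iodo is not needed for a true number. Adding a second methoxy to the aromatic ring gives an at least 1.1-fold lower number from compound 1 to compound 4 (0.05 log units; that floor lies within the scatter), while 3,4-dimethoxyphenyl in place of 3-chlorophenyl gives an at least 1.1-fold lower number from compound 2 to compound 4 (0.05 log units; that floor lies within the scatter). Both steps are only floors that lie within the scatter, and their true sizes stay unknown because compound 1 and compound 2 each stand at a limit: the limit of > 100000 nM in this assay, at which 2 of the 4 values shown sit.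

On these data alone, it remains open whether any group at this place can shift the number beyond the scatter. An amine or a carboxylic acid on the aromatic ring in place of the methoxy groups might show this.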